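Chlorobenzyl purines: adding a second chloro to compound 2

A few compounds are considered here, and "the series" means these few. Any claim that something is new, unique, unknown or untested is made for them only; others in the source may bear on it.

Three compounds have numbers in a functional assay on ACHN cells (Homo sapiens) for cytotoxicity, read by sulforhodamine B assay, with a stated time of 48 h; a lower number here means a stronger inhibitor of growth, a higher number a weaker inhibitor of growth. Compound 1 `ClCc1ccccc1Cn1cnc2c(Cl)ncnc21` gives 2700 nM. Compound 2 `ClCc1ccccc1Cn1cnc2ncnc(Cl)c21` gives 1990 nM, the second highest of the three and within the scatter of both neighbours: compound 1 sits near it, and compound 3 `ClCc1cccc(Cn2cnc3nc(Cl)nc(Cl)c32)c1` gives 1120 nM, also within the scatter. So no order can be read among the three in this assay.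

Compound 4 `ClCc1ccccc1Cn1cnc2nc(Cl)nc(Cl)c21` differs from compound 2 by chloro in place of hydrogen on an aromatic carbon. Among the measured compounds shown here, no measured pair shows this change alone. Compound 3, which also carries two chloro groups, gives 1120 nM, so the step of a 1.4-fold lower number from compound 2 to compound 4 (0.15 log units; within the scatter) is expected to be small and toward a lower number, not clearly beyond the scatter. Compound 4 is therefore estimated at 1400 nM, with a range of 500 nM to 4000 nM.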

Compound 4, concentration for 50% growth inhibition: 350 nM
The estimate for compound 4 lay 4.0-fold (0.60 log units) above the measured number, and the stated range ends above it.
By their numbers in this assay, from the lowest: compound 4; then compounds 3, 2 and 1 (each within the scatter of the next, the first and the last beyond it).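

In this assay, among the compounds shown here, chloro in place of hydrogen on an aromatic carbon between two ring nitrogen atoms gives a 5.7-fold lower number from compound 2 to compound 4 (0.75 log units; beyond the scatter) and is the first single-place step. The change at this position gives a difference beyond the scatter, whereas compound 1, compound 2 and compound 3 alone allowed no order. Nothing available explains this difference.

From the compounds shown here alone, whether the lower number is specific to chloro remains open, as an amine or a methoxy group at this position would show. Going by these compounds, whether the same step holds with the chloromethyl group elsewhere on the benzyl ring also remains open.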